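Methylating the phenol of a cytotoxic chromene

The source may report more compounds than this note shows. Statements on the series, on what has been measured and on what is new or still open speak of the compounds shown alone.

Of the compounds shown here, two have so far been measured in a functional assay on MCF7 cells (Homo sapiens) for cytotoxicity, read by MTT assay, with a stated time of 7 days; a higher number here means that more compound is needed for the effect, a lower number that less compound is needed. Compound 1 `COC(C)(C)/C=C/c1cc(C(C)=O)ccc1O[C@@H]1O[C@H](CO)[C@@H](O)[C@H](O)[C@H]1O` gives 44 ug/mL. Compound 2 `CC(=O)c1cc2c(cc1O)OC(C)(C)C=C2` gives 2 ug/mL, the lowest of the two numbers, and the gap to compound 1 lies beyond the usual scatter of this kind of measurement. Compound 3 `COc1cc2c(cc1C(C)=O)C=CC(C)(C)O2` has not yet been measured in this assay. It differs from compound 2 in a single place: methyl in place of hydrogen on an oxygen on an aromatic ring. Among the measured compounds there is no pair that shows what hydroxy to methoxy does on this core, so no step is available to lean on. The change from compound 2 to compound 3 is expected to shift the number only modestly, toward a higher value, a step estimated as a 2.0-fold higher number from compound 2 to compound 3 (0.30 log units; within the scatter). For compound 3 in this assay the estimated value is 4 ug/mL, with an expected range from 1 ug/mL to 15 ug/mL.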

Compound 3, concentration for half-maximal effect: 29 ug/mL
Compound 3: the middle estimate sits 7.3-fold (0.86 log units) below what was measured; the measured number lies above the stated range.
By their numbers in this assay, from the lowest: compound 2; then compounds 3 and 1 (each within the scatter of the next).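

On the shared core, the hydrogen on this oxygen on an aromatic ring proves far from interchangeable with methyl in this assay: hydroxy to methoxy gives a 15-fold higher number from compound 2 to compound 3 (1.16 log units; beyond the scatter), so a single added carbon at this place is enough for a large change in the number. Among the compounds shown here, the earlier compounds held no pair that isolated this oxygen, so this is the first direct reading of the change, and it rests on one pair alone. Nothing at hand says why the number rises so far.

On these data alone, whether the step follows from losing the hydrogen or from adding the methyl stays open, and an ethyl or acetyl group on this oxygen, or an amine in place of the hydroxy, would bear on that. As far as these compounds go, it also remains open whether the same change would give a step of this size on any other core.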